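Working notes: cutting the chain back to compound 3

The source may hold more compounds than are shown below. What is called first, only, known or untested is meant among the compounds shown, and "the series" means these compounds.

Measured so far in a functional assay on SK-MEL-28 cells (Homo sapiens) for inhibition, read by colorimetric assay and MTT assay, with a stated time of 72 h (a lower number here means a stronger inhibitor, a higher number a weaker inhibitor), for this series:
- compound 1 `CCCCOc1ncc(-c2ccccc2OC)n1C` gives 82000 nM as its value
- compound 2 `C#CCCCCOc1ncc(-c2ccccc2OC)n1C` gives 38000 nM as its value

Compound 2 holds the lower of the two numbers. Going by the values given here, the only measured step is a 2.2-fold lower number from compound 1 to compound 2 (0.33 log units; beyond the scatter) and it is modest.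

Compound 3 `COc1ccccc1-c1cnc(OC)n1C` is not yet measured. It differs from compound 2 in one place hydrogen in place of pent-4-yn-1-yl on a saturated chain carbon bound to an oxygen on an aromatic ring that is, hydrogen in place of pent-4-yn-1-yl on a saturated chain carbon bound to an oxygen on an aromatic ring, so (hex-5-yn-1-yl)oxy becomes methoxy. The measured step bears on this only in part, since it concerns ethynyl in place of hydrogen on the chain, not loss of the chain. The step of a 2.2-fold lower number from compound 1 to compound 2 (0.33 log units; beyond the scatter) still suggests a move to a higher number of similar or somewhat larger size. The estimated step is a 2.9-fold higher number from compound 2 to compound 3 (0.46 log units; beyond the scatter) and it is expected to hold in this assay with wide uncertainty. Compound 3 is expected at 110000 nM (estimated range 45000 nM to 300000 nM).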

Compound 3, half-maximal inhibitory concentration: > 100000 nM
Compound 3: only a limit was reported; the forecaster's own chance of this, stated with the estimate: 35%; the middle value does not contradict the limit.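

Compound 3, with methoxy in place of (hex-5-yn-1-yl)oxy, gives > 100000 nM in this assay, which is a limit of the assay and not a number. Loss of pent-4-yn-1-yl on the saturated chain carbon bound to an oxygen on an aromatic ring gives an at least 2.6-fold higher number from compound 2 to compound 3 (0.42 log units; beyond the scatter), with a floor beyond the scatter, so cutting the chain back here costs activity against the alkyne chain, whereas loss of propyl gives an at least 1.2-fold higher number from compound 1 to compound 3 (0.08 log units; that floor lies within the scatter), with a floor within the scatter, and that step alone does not set the two compounds apart. Both steps are floors and not sizes: the limit of > 100000 nM in this assay, at which 1 of the 3 values shown sits.

The compounds shown leave open whether a chain longer than hex-5-yn-1-yl would bring the number lower. Going by these compounds, an amine or a carboxylic acid on the chain in place of ethynyl also stays open.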